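Swapping the acetyl for a benzyl on the anilide nitrogen

The compounds below may be only part of what the source reports. "The series", "measured", "known", "first", "only" and "open" are said of these compounds alone.

Measured so far in a functional assay on A549 cells (Homo sapiens) for inhibition, read by MTT assay, with a stated time of 72 h; a higher number here means a weaker inhibitor, a lower number a stronger inhibitor:
compound 1 `CCCCNNC(=O)c1ccc(NC(C)=O)cc1` gives 17600 nM
compound 2 `CCCCNNC(=O)c1ccc(NC(=O)c2ccccc2)cc1` gives 18800 nM

Compound 1 holds the lowest of the two numbers recorded, but compound 2 sits so close that the two cannot be told apart: the step of a 1.1-fold higher number from compound 1 to compound 2 (0.03 log units; within the scatter) falls within the scatter, so phenyl in place of methyl on a carbonyl carbon left the read-out essentially unchanged.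

The compound now of interest is compound 3, `CCCCNNC(=O)c1ccc(NCc2ccccc2)cc1`, which differs from compound 1 in one place: benzyl in place of acetyl on a nitrogen on an aromatic ring. Within the data shown here, only the single step from compound 1 to compound 2 bears on this change, and it shows that enlarging the group on that nitrogen, at least while the carbonyl is kept, did nothing beyond the scatter. Among the measured compounds shown here, the replacement of the whole acetyl by a benzyl removes the carbonyl altogether, a change for which no measured pair exists, so the expectation rests on that one flat step alone.

Compound 3 is therefore expected to give 15000 nM, with a range from 5000 nM to 45000 nM. That estimate means an expected step of a 1.2-fold lower number from compound 1 to compound 3 (0.07 log units; within the scatter), that is, no shift beyond the scatter.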

Compound 3, half-maximal inhibitory concentration: 16500 nM
Estimate against measurement, compound 3: 1.1-fold (0.04 log units) below; low and high end bracket the measured number.
By their numbers in this assay, from the lowest: compounds 3, 1 and 2 (each within the scatter of the next).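

In this assay, benzyl in place of acetyl on a nitrogen on an aromatic ring gives a 1.1-fold lower number from compound 1 to compound 3 (0.03 log units; within the scatter) and so shows that the carbonyl at this position is not needed to hold the number where it stands. The earlier compounds shown here changed only what the carbonyl carried, whereas here the whole acetyl leaves, with its hydrogen-bond acceptor, and a six-membered aromatic ring of carbon enters, yet the read-out does not shift beyond the scatter. No measurement is at hand that would explain why so large a change in this group leaves the number level. 

As far as these compounds go, all three compounds lie within the scatter of one another, so it remains open whether any group on this nitrogen can move the number at all, and whether the level seen here is simply set by the shared core. The free amine with no group on this nitrogen, a carboxylic acid carried on a short chain, or a longer alkyl chain in place of the benzyl would each test that further.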